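From 4-methylbenzyl to 4-fluorobenzyl at the assay limit

The source may report more compounds than this note shows. Statements on the series, on what has been measured and on what is new or still open speak of the compounds shown alone.

Measured in a functional assay on HepG2 cells (Homo sapiens) for inhibition, read by MTT assay, with a stated time of 48 h; a higher number here means a weaker inhibitor, a lower number a stronger inhibitor:
- Compound 1 `CCSc1nnc(-c2cc(OC)c(OC)c(OC)c2)n1-c1ccc(N(C)C)cc1`: > 60000 nM, a limit
- Compound 2 `COc1cc(-c2nnc(SCc3ccccc3)n2-c2ccc(N(C)C)cc2)cc(OC)c1OC`: > 60000 nM, a limit
- Compound 3 `COc1cc(-c2nnc(SCc3ccc(C)cc3)n2-c2ccc(N(C)C)cc2)cc(OC)c1OC`: > 60000 nM, a limit

Compound 3 stands at > 60000 nM, which is a limit and not a number. The whole series sits at one value, (the limit of > 60000 nM in this assay, at which 3 of the 3 values shown sit). Compound 4 `COc1cc(-c2nnc(SCc3ccc(F)cc3)n2-c2ccc(N(C)C)cc2)cc(OC)c1OC` is the next structure, and it differs from compound 3 by fluoro in place of methyl on an aromatic carbon. In words, this is fluoro in place of methyl on an aromatic carbon, para to a large group.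

Among the compounds with values here, three measured steps bear on the change: a step that the two limits leave unreadable from compound 1 to compound 2, a step that the two limits leave unreadable from compound 1 to compound 3 and a step that the two limits leave unreadable from compound 2 to compound 3. The last is the closest, as it changes the same ring position, but none of the three gives a size. No step beyond the scatter is therefore expected in this assay, and no direction can be supported. The expected step is a number no higher from compound 3 to compound 4 (the limit leaves the size open). For compound 4 the estimate is 60000 nM, with an expected range from 20000 nM to 120000 nM.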

Compound 4, half-maximal inhibitory concentration: 26400 nM
Beside the measured number, compound 4's estimate is 2.3-fold (0.36 log units) above it; the range from low to high includes it.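

The aromatic carbon para to a large group proves able to move the read-out: in this assay, fluoro in place of methyl gives an at least 2.2-fold lower number from compound 3 to compound 4 (0.35 log units; beyond the scatter). Fluoro in place of hydrogen at the same carbon gives an at least 2.2-fold lower number from compound 2 to compound 4 (0.35 log units; beyond the scatter), and 4-fluorophenyl in place of methyl on the saturated chain carbon bound to a sulfur gives an at least 2.2-fold lower number from compound 1 to compound 4 (0.35 log units; beyond the scatter). Compound 4 is thus the only one of the four with a measured number rather than a limit: the limit of > 60000 nM in this assay, at which 3 of the 4 values shown sit.

From the compounds shown here alone, each of these steps starts from a limit, so its full size stays open. The compounds shown also leave open whether chloro or a nitrile on that carbon, or fluoro elsewhere on the same ring, would give a lower number than compound 4.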